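Chlorophenyl Exchange on a Second Hydrazide Scaffold

This account rests on a few compounds, and the source may have more. Where it says the series, first, only, none or still open, it means among the compounds named here.

Three hydrazide sulfonamides were tested in a functional assay on SGC-7901 cells (Homo sapiens) for antiproliferative activity, read by MTT assay, with a stated time of 24 h; a lower number here means a stronger inhibitor, a higher number a weaker inhibitor. Compound 1 `Cc1ccc(C(=O)NNC(=O)c2cccc(NS(=O)(=O)c3cnc(O)nc3O)c2)cc1` gave 10100 nM. Compound 2 `O=C(NNC(=O)c1ccccc1Cl)c1cccc(NS(=O)(=O)c2cnc(O)nc2O)c1` carries the change 2-chlorophenyl in place of 4-methylphenyl on a carbonyl carbon made on compound 1; in this assay compound 2 gave 6070 nM. The step of a 1.7-fold lower number from compound 1 to compound 2 (0.22 log units; within the scatter) is therefore modest. Compound 3 `Cc1ccc(C(=O)NNC(=O)c2ccccc2NS(=O)(=O)c2cnc(O)nc2O)cc1` has the same atoms as compound 1 joined differently, and the difference between the two cores is not broken down here; in this assay compound 3 gave 15500 nM, the highest of the three numbers, though its gap to compound 1 lies within the scatter, while its gap to compound 2 lies beyond it.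

Compound 4 `O=C(NNC(=O)c1ccccc1NS(=O)(=O)c1cnc(O)nc1O)c1ccccc1Cl` has not yet been measured. It differs from compound 3 by 2-chlorophenyl in place of 4-methylphenyl on a carbonyl carbon, the same change that separates compound 1 from compound 2, at the same kind of place. Because the measured step of a 1.7-fold lower number from compound 1 to compound 2 (0.22 log units; within the scatter) was small, the step of a 1.6-fold lower number from compound 3 to compound 4 (0.21 log units; within the scatter) is expected to be of similar size, an expectation resting on that single pair only. In this assay compound 4 is therefore estimated at 9500 nM, expected to fall between 4000 nM and 22000 nM.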

Compound 4, half-maximal inhibitory concentration: 2410 nM
For compound 4 the middle estimate is 3.9-fold (0.60 log units) above the measured one, and the stated range ends above it.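

In this assay, 2-chlorophenyl in place of 4-methylphenyl on a carbonyl carbon gave a 6.4-fold lower number from compound 3 to compound 4 (0.81 log units; beyond the scatter), a step beyond the scatter on the core of compound 3. Set beside the earlier step, the size of this change did not carry over unchanged from one core to the other: the same change on two cores in this assay, a 1.7-fold lower number (0.22 log units; within the scatter) from compound 1 to compound 2 and a 6.4-fold lower number (0.81 log units; beyond the scatter) from compound 3 to compound 4, 3.9-fold (0.59 log units) apart, beyond the scatter of two such steps. For the compounds shown here, only two pairs stand behind this comparison, so it shows that one size of step cannot be assumed across these two cores, but it does not show why they differ or what size the step would take on a further core.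

The compounds shown leave open whether the larger step on the core of compound 3 is particular to 2-chlorophenyl or would also appear with other groups on the same carbonyl carbon. They also leave open how an amine, a carboxylic acid or a longer alkyl chain in that place would read in this assay on either core.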